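The compounds below may be only part of what the source reports. "The series", "measured", "known", "first", "only" and "open" are said of these compounds alone.

Measured compounds:
compound 1, `CCN(CC)C(=O)CO/N=C(\c1ccc(SC)cc1)c1cccc2ccccc12`: 30000 nM
compound 2, `CSc1ccc(/C(=N\OCCCCN2CCCCC2)c2cccc3ccccc23)cc1`: 18000 nM

In a functional assay on MDA-MB-231 cells (Homo sapiens) for antiproliferative activity, read by MTT assay, with a stated time of 24 h (a lower number here means that less compound is needed, a higher number that more compound is needed for the effect), compound 1 gives 30000 nM. In this assay, within the data shown here, compound 2 gives 18000 nM, the lower of the two numbers, with compound 1 as its only neighbour; the step of a 1.7-fold lower number from compound 1 to compound 2 (0.22 log units; within the scatter) keeps the pair within the scatter. Compound 3, `CCN(CCCCO/N=C(\c1ccc(SC)cc1)c1cccc2ccccc12)Cc1ccccc1`, has not yet been measured. It differs from compound 2 by benzyl(ethyl)amino in place of piperidin-1-yl on a saturated chain carbon, four bonds along the chain from an oxygen. Among the measured compounds shown here, the one measured step, a 1.7-fold lower number from compound 1 to compound 2 (0.22 log units; within the scatter), changed the chain end attached to the oxygen, the same region that the change from compound 2 to compound 3 touches, and that step stayed within the scatter. On this basis no step beyond the scatter in this assay is expected. Compound 3 is therefore estimated to give about 15000 nM, in a range from 5000 nM to 45000 nM. The step this estimate means, a 1.2-fold lower number from compound 2 to compound 3 (0.08 log units; within the scatter), is expected to stay within the scatter.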

Compound 3, half-maximal effective concentration: > 50000 nM
Compound 3 ended at the assay's limit (the forecaster's own chance of this, stated with the estimate: 10%); at least 3.3-fold (0.52 log units) between middle value and limit.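

In this assay compound 3 reaches a limit of the assay, > 50000 nM, and this is a limit, not a number. Benzyl(ethyl)amino in place of piperidin-1-yl gives the only step shown that lies beyond the scatter, an at least 2.7-fold higher number from compound 2 to compound 3 (0.44 log units; beyond the scatter), so the amine at this place, on a saturated chain carbon, four bonds along the chain from an oxygen, can change the read-out, which a 1.7-fold lower number from compound 1 to compound 2 (0.22 log units; within the scatter) did not show. The full size of this step cannot be read, only its lower bound: the limit of > 50000 nM in this assay, at which 1 of the 3 values shown sits.

The compounds shown leave open whether the benzyl or the ethyl group of the new amine goes with this change. They also leave open what a smaller open-chain amine such as dimethylamino, or a morpholin-4-yl ring, would give at the same place.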